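The source may hold more compounds than are shown below. What is called first, only, known or untested is meant among the compounds shown, and "the series" means these compounds.

In a functional assay on CLL cells (Homo sapiens) for cytotoxicity, read by MTT assay, with a stated time of 48 h (a lower number here means that less compound is needed, a higher number that more compound is needed for the effect), compound 1 `C=C(CC)C(=O)c1ccc(OCC(=O)Nc2nc3ccccc3s2)c(Cl)c1Cl` gives 1500 nM and compound 2 `C=C(CC)C(=O)c1ccc(OCC(=O)Nc2ccc(/C=C/C(=O)OCC)cc2)c(Cl)c1Cl` gives 1700 nM. These two numbers lie within the usual scatter of each other, so compound 1 cannot be ranked ahead of compound 2. The next molecule, compound 3 `C=C(CC)C(=O)c1ccc(OCC(=O)NCO[N+](=O)[O-])c(Cl)c1Cl`, keeps the core of compound 1 and changes only the group on the amide-type nitrogen: (nitrooxy)methyl in place of 1,3-benzothiazol-2-yl on an amide-type nitrogen. In words, (nitrooxy)methyl takes the place of 1,3-benzothiazol-2-yl, so the new group has no ring.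

Within the data shown here, no two measured compounds differ in just one place, so no measured step can serve as a guide. Among the measured compounds shown here, the only evidence is that compound 1 at 1500 nM and compound 2 at 1700 nM both carry a ring-bearing group on that nitrogen, and no ringless example has been measured. A modest move is therefore expected, with wide uncertainty. In this assay, the estimated step is a 2.0-fold higher number from compound 1 to compound 3 (0.30 log units; within the scatter), towards a higher number, meaning that more compound would be needed. For compound 3, the expected value is 3000 nM, with an estimated range of 900 nM to 10000 nM.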

Compound 3, half-maximal effective concentration: 4100 nM
Compound 3: middle estimate off by 1.4-fold (0.14 log units), on the low side, within the range that was stated.
By their numbers in this assay, from the lowest: compounds 1 and 2 (each within the scatter of the next); then compound 3.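

In this assay, among these compounds, replacing 1,3-benzothiazol-2-yl with (nitrooxy)methyl on the amide-type nitrogen gives a 2.7-fold higher number from compound 1 to compound 3 (0.44 log units; beyond the scatter) and provides the first single-change comparison at this position. It shows that the number responds to the group placed there, although the step is modest and beyond the scatter. The change removes both aromatic rings, reduces the group's heavy atoms and brings in oxygen, all at once, and no measurement on hand bears on the reason for the step.

As far as these compounds go, it remains open whether the higher number goes with losing the rings or with gaining the nitrooxy group, a question that a plain methyl or an unsubstituted phenyl ring on the same nitrogen could help to separate. Among the compounds shown here, with only this one step to read, it is also unclear how a longer alkyl chain, an amine or a carboxylic acid at this position would compare.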